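The source may hold more compounds than are shown below. What is called first, only, known or untested is meant among the compounds shown, and "the series" means these compounds.

Measured so far:
compound 1 `CC(C)C(c1ccc(-c2ccc3cccc(F)c3c2)[nH]c1=O)N1CCCCS1(=O)=O`: 14 nM
compound 2 `CC(C)C(Cc1nnc[nH]1)c1ccc(-c2ccc3cccc(F)c3c2)[nH]c1=O`: 10 nM
compound 3 `CC(C)C(Cc1noc(=O)[nH]1)c1ccc(-c2ccc3cccc(F)c3c2)[nH]c1=O`: 34 nM

In an assay on CHO cells for displacement of a labelled ligand from prostaglandin E2 receptor EP3 subtype (Homo sapiens), read by radioligand binding (a lower number here means a stronger inhibitor, a higher number a weaker inhibitor), compound 3 gives 34 nM and stands highest of the three; the nearest is compound 1, with a 2.4-fold higher number from compound 1 to compound 3 (0.39 log units; beyond the scatter), and the furthest compound 2, with a 3.4-fold higher number from compound 2 to compound 3 (0.53 log units; beyond the scatter). Compound 4 `CC(C)C(c1ncc[nH]1)c1ccc(-c2ccc3cccc(F)c3c2)[nH]c1=O` differs from compound 3 in one place: a group of 5 heavy atoms (3 carbon, 2 nitrogen; one five-membered aromatic ring with 2 hetero atoms) in place of a group of 7 heavy atoms (3 carbon, 2 nitrogen, 2 oxygen; one five-membered aromatic ring with 3 hetero atoms), on a saturated chain carbon bound to an aromatic carbon and a saturated chain carbon. Among the measured compounds shown here, two measured steps bear on this. The swap of one azole for another in this part of the molecule gave a 1.4-fold lower number from compound 1 to compound 2 (0.15 log units; within the scatter), so such ring changes need not move the number at all; yet the step to the ring carrying two oxygens, a 3.4-fold higher number from compound 2 to compound 3 (0.53 log units; beyond the scatter), did raise it. The group entering in compound 4 carries no oxygen and sits directly on the chain carbon, as in compounds 1 and 2, so compound 4 is expected to move back toward their level, a modest fall of a 2.3-fold lower number from compound 3 to compound 4 (0.36 log units; beyond the scatter) in this assay. Compound 4 is thus estimated at 15 nM, in a range from 6 nM to 40 nM.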

Compound 4, inhibition constant in the prostaglandin E2 receptor EP3 subtype assay: 7.3 nM
Compound 4: the middle estimate sits 2.1-fold (0.31 log units) above what was measured; the range from low to high includes it.
By their numbers in the prostaglandin E2 receptor EP3 subtype assay, from the lowest: compounds 4, 2 and 1 (each within the scatter of the next); then compound 3.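

In the prostaglandin E2 receptor EP3 subtype assay, compound 3 gives 34 nM and compound 4 gives 7.3 nM. In the prostaglandin E2 receptor EP3 subtype assay, 1H-imidazol-2-yl on this saturated chain carbon gave a 4.7-fold lower number from compound 3 to compound 4 (0.67 log units; beyond the scatter), which shows that the ring with two oxygens can be replaced here with a clear drop in the number. In the prostaglandin E2 receptor EP3 subtype assay, the imidazole also stays within the scatter of both other groups, with a 1.4-fold lower number from compound 2 to compound 4 (0.14 log units; within the scatter) and a 1.9-fold lower number from compound 1 to compound 4 (0.28 log units; within the scatter), so the ring at this position need not be carried on the methyl link of (4H-1,2,4-triazol-3-yl)methyl. In a physicochemical assay for solubility, measured as kinetic solubility, at pH 2 (a lower number here means a less soluble compound, a higher number a more soluble compound), compound 3 gives 18200 nM and compound 4 gives 31800 nM. In the physicochemical assay, the same change gave a 1.7-fold higher number from compound 3 to compound 4 (0.24 log units; within the scatter), so the step in binding came without a shift in solubility beyond the scatter.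

Nothing available explains why compound 3 stands apart from the other three compounds. From the compounds shown here alone, whether an amine or a carboxylic acid on this chain carbon would keep the number at the level of compound 4 remains open.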